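Chlorotriazine series: amine swap and stereocentre effects

This account rests on a few compounds, and the source may have more. Where it says the series, first, only, none or still open, it means among the compounds named here.

Three compounds are measured in an ADME assay on the whole organism for inhibition, with Echinochloa crus-galli var. formosensis as the target, with a stated time of 4 days; a higher number here means a weaker inhibitor, a lower number a stronger inhibitor. Compound 1, `CCN(CC)c1nc(Cl)nc(N[C@H](C)c2ccccc2)n1`, gives 24000 nM. Compound 2, `CCCN(C)c1nc(Cl)nc(N[C@H](C)c2ccccc2)n1`, gives 9770 nM. Compound 3, `CCCN(C)c1nc(Cl)nc(N[C@@H](C)c2ccccc2)n1`, gives 380 nM, the lowest number of the three, with compound 2 nearest and compound 1 furthest from it.

Two changes are covered. From compound 2 to compound 3 the change is the two compounds have the same atoms and bonds and differ only in configuration as drawn: 1 of 1 stereo elements differ; a stereocentre at a saturated chain carbon is drawn R in compound 2 and S in compound 3, and the step is a 26-fold lower number from compound 2 to compound 3 (1.41 log units; beyond the scatter); this step is tied to the drawn configuration because of the fact that compounds 2 and 3 differ only in the configuration as drawn. From compound 2 to compound 1 the change is diethylamino in place of methyl(propyl)amino on an aromatic carbon, and the step is a 2.5-fold higher number from compound 2 to compound 1 (0.39 log units; beyond the scatter).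

Compound 4, `CCN(CC)c1nc(Cl)nc(N[C@@H](C)c2ccccc2)n1`, is not yet measured in this assay. It differs from compound 3 by diethylamino in place of methyl(propyl)amino on an aromatic carbon, which is the same change already seen once, from compound 2 to compound 1; it occurs twice in all among the compounds shown, at the same place on the shared core both times. The expectation for compound 4 rests on carrying that earlier step over onto compound 3, whose value in this assay is 380 nM, and the step expected from compound 3 to compound 4 is accordingly a 2.5-fold higher number from compound 3 to compound 4 (0.40 log units; beyond the scatter), set beside the measured one, and kept loose. Compound 4 is therefore estimated to give 950 nM in this assay, with a range from 300 nM to 3000 nM.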

Compound 4, half-maximal inhibitory concentration: 257 nM
The estimate for compound 4 lay 3.7-fold (0.57 log units) above the measured number, and the stated range ends above it.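

In this assay, diethylamino in place of methyl(propyl)amino on the compounds drawn S gives a 1.5-fold lower number from compound 3 to compound 4 (0.17 log units; within the scatter), so this pair cannot be told apart, whereas the same change on the compounds drawn R gave a 2.5-fold higher number from compound 2 to compound 1 (0.39 log units; beyond the scatter); the change therefore does not carry over at one size between the two configurations: the same change on two cores in this assay, a 2.5-fold higher number (0.39 log units; beyond the scatter) from compound 2 to compound 1 and a 1.5-fold lower number (0.17 log units; within the scatter) from compound 3 to compound 4, 3.6-fold (0.56 log units) apart, beyond the scatter of two such steps. For the compounds shown here, with diethylamino in place, the drawn configuration again gives a large step, a 93-fold lower number from compound 1 to compound 4 (1.97 log units; beyond the scatter), in the same direction as a 26-fold lower number from compound 2 to compound 3 (1.41 log units; beyond the scatter), and configuration is the only difference within this pair: the fact that compounds 1 and 4 differ only in the configuration as drawn. These two pairs show that the size of the amine step depends on the drawn configuration here, but they do not show why, nor how the change would behave on any other core.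

Still open, as far as these compounds go, is whether other amines in the same place, such as dimethylamino or dipropylamino, would also depend on the drawn configuration. Also open, from the compounds shown here alone, is whether the pattern would survive a methoxy group in place of the chloro group.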